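Aryl group swap on the shared core: tolerability notes

This account rests on a few compounds, and the source may have more. Where it says the series, first, only, none or still open, it means among the compounds named here.

Measured so far:
- compound 1 `Cc1oc(-c2ccc(Cl)cc2)nc1CN1CCC(C(=O)NCCCN2C[C@H](C)C[C@H](C)C2)CC1`: in an ADME assay on Huh7.5.1 cells (Homo sapiens) for cytotoxicity, read by ATP content, with a stated time of 48 h (a lower number here means that less compound is tolerated, a higher number that more compound is tolerated), compound 1 gives 11500 nM
- compound 2 `Cc1ccccc1-c1nc(CN2CCC(C(=O)NCCCN3CCCC(CC(C)C)C3)CC2)c(C)o1`: in this assay compound 2 gives 4640 nM

Compound 1 stands at the highest of the two numbers in this assay; compound 2 sits below it, and that gap is beyond the scatter. Among the compounds with values here, no single-change pair links compound 1 and compound 2, so nothing more than their two numbers can be said of that comparison, and compound 2 differs from compound 1 in more than one place.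

Compound 3 `Cc1ccc(-c2nc(CN3CCC(C(=O)NCCCN4C[C@H](C)C[C@H](C)C4)CC3)c(C)o2)c(C)c1` is next in line. Relative to compound 1 the change is 2,4-dimethylphenyl in place of 4-chlorophenyl on an aromatic carbon. Within the data shown here, no measured step of this kind exists, so the expected direction rests on the change alone.

The expectation for compound 3 is a small move, if any, within the scatter, leaning slightly downward, as an expected step of a 1.3-fold lower number from compound 1 to compound 3 (0.11 log units; within the scatter). Compound 3 is estimated at 9000 nM, with a range from 4000 nM to 20000 nM.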

Compound 3, half-maximal cytotoxic concentration: 4110 nM
Beside the measured number, compound 3's estimate is 2.2-fold (0.34 log units) above it, and the stated range covers the measured number.
By their numbers in this assay, from the lowest: compounds 3 and 2 (each within the scatter of the next); then compound 1.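

The series now has its first single-change pair: in this assay, 2,4-dimethylphenyl in place of 4-chlorophenyl, on the aromatic carbon next to the ring nitrogen and next to the ring oxygen, gives a 2.8-fold lower number from compound 1 to compound 3 (0.45 log units; beyond the scatter), so the aryl group at this position does affect how much compound is tolerated. The step is modest and rests on this one pair, in which the chlorine leaves, the group entering is carbon only, and the six-membered aromatic ring stays, so the pair cannot show which part of the swap accounts for the lower number. No measured property of these compounds bears on the step, and its origin stays unassigned.

Still open, on these data alone, is whether the lower number follows from losing the chlorine or from gaining the methyl groups, and whether an unsubstituted phenyl, a 4-methylphenyl or a 4-fluorophenyl group would stay closer to compound 1. Also open, as far as these compounds go, is how a more polar aryl substituent such as a carboxylic acid or an amine would read in this assay, and compound 2 differs from the others in more than one place, so it cannot settle either question.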